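The source may report more compounds than this note shows. Statements on the series, on what has been measured and on what is new or still open speak of the compounds shown alone.

Measured so far in an in vitro functional assay on HEK285-7 cells for antagonist activity at prostaglandin D2 receptor 2 (Homo sapiens), read by BRET and beta-arrestin recruitment; on this read-out higher numbers stand for weaker inhibition and lower numbers for stronger inhibition:
Compound 1, `O=C(O)Cc1sc(COc2ccc(Cl)cc2)nc1-c1ccc(Cl)cc1`, gives 370 nM.
Compound 2, `O=C(O)Cc1sc(C(c2ccc(F)cc2)c2ccc(F)cc2)nc1-c1ccnc(N2CCCC2)c1`, gives only a limit of the assay, > 100000 nM.
Compound 3, `O=C(O)Cc1sc(C(c2ccccc2)c2ccccc2)nc1-c1ccc(C(F)(F)F)cc1`, also gives only a limit of the assay, > 100000 nM.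

Compound 2 thus stands at the limit of > 100000 nM in this assay, at which 2 of the 3 values shown sit; no number for it is known, and the two limits cannot be ordered against each other. Compound 4, `O=C(O)Cc1sc(C(c2ccc(F)cc2)c2ccc(F)cc2)nc1-c1cn[nH]c1`, differs from compound 2 in one place: 1H-pyrazol-4-yl in place of 2-(pyrrolidin-1-yl)pyridin-4-yl on an aromatic carbon. For the measured compounds named here, no step between two measured compounds of this kind is known, so the direction of this change cannot be read from the data. As compound 2 shows only a limit, even a real gain in inhibition might still leave compound 4 at that limit. A modest gain is nonetheless expected, the step from compound 2 to compound 4 estimated as an at least 2.5-fold lower number from compound 2 to compound 4 (0.39 log units; beyond the scatter). Compound 4 is expected near 40000 nM, within 3000 nM to 100000 nM.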

Compound 4, half-maximal inhibitory concentration: 220 nM
Compound 4: middle estimate off by 180-fold (2.26 log units), on the high side; the measured number lies below the stated range.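

In this assay, replacing 2-(pyrrolidin-1-yl)pyridin-4-yl with 1H-pyrazol-4-yl while the rest of the molecule stays the same gives an at least 450-fold lower number from compound 2 to compound 4 (2.65 log units; beyond the scatter). This shows that the group on this aromatic carbon, next to the ring nitrogen, can by itself have a very large effect on inhibition. The true size of the step is unknown, as its starting point is a limit and not a number: the limit of > 100000 nM in this assay, at which 2 of the 4 values shown sit.

Which part of the change matters remains open, as the step swaps the whole group. A plain pyridin-4-yl group or a 1-methylpyrazol-4-yl group at this position could help to separate these effects.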